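The source may hold more compounds than are shown below. What is called first, only, known or untested is meant among the compounds shown, and "the series" means these compounds.

Measured in a functional assay on A549 cells (Homo sapiens) for antiproliferative activity, read by MTT assay, with a stated time of 72 h; on this read-out lower numbers stand for stronger inhibition and higher numbers for weaker inhibition:
compound 2 `CCCNC(=O)c1cc(Oc2ccc(NC(=O)c3cc4cccnc4n(-c4ccc(F)cc4)c3=O)cc2)ccn1` gives 62 nM
compound 1 `CNC(=O)c1cc(Oc2ccc(NC(=O)c3cc4cccnc4n(-c4ccc(Br)cc4)c3=O)cc2)ccn1` gives 1050 nM

Of these two numbers, compound 2 holds the lower one, and its gap to compound 1 lies well beyond the scatter of this assay, so compound 2 is the more potent of the two measured compounds. Compound 1 and compound 2 differ in more than one part of the structure, so their values alone do not show which part of the molecule accounts for the gap.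

Compound 3 `CCCNC(=O)c1cc(Oc2ccc(NC(=O)c3cc4cccnc4n(-c4ccc(Br)cc4)c3=O)cc2)ccn1` is the compound still to be measured. It differs from compound 2 in a single place: bromo in place of fluoro on an aromatic carbon. For the measured compounds named here, no pair of measured compounds isolates this exchange, so there is no measured step to lean on directly. Going by the values given here, the only measured compound carrying the bromo group is compound 1, whose higher number in this assay points, if weakly, toward the bromo analogue being less potent. A modest step upward in the number is therefore expected for compound 3, of about a 2.4-fold higher number from compound 2 to compound 3 (0.38 log units; beyond the scatter). Compound 3 is estimated at 150 nM in this assay, most likely between 40 nM and 600 nM.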

Compound 3, half-maximal inhibitory concentration: 150 nM
The estimate for compound 3 equals the measured number at the digits printed; low and high end bracket the measured number.
By their numbers in this assay, from the lowest: compound 2; then compound 3; then compound 1.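

In this assay, the exchange of 4-fluorophenyl for 4-bromophenyl can now be read on its own, as a 2.4-fold higher number from compound 2 to compound 3 (0.38 log units; beyond the scatter), so the halogen at this ring position does affect the antiproliferative number, and fluoro gives the stronger inhibition of the two. Compound 3 also isolates a second change: with the bromo group held constant, ethyl in place of hydrogen on the saturated chain carbon bound to the amide-type nitrogen gives a 7.0-fold lower number from compound 1 to compound 3 (0.85 log units; beyond the scatter). Each step lies beyond the scatter and points the same way, so the large gap between compound 1 and compound 2 cannot be credited to the halogen or the chain alone.

No measurement shown explains why either change moves the number. Also open, going by these compounds, are whether the halogen exchange has the same size on the chain of compound 1, and how chloro, a methoxy group or plain hydrogen at this ring position, or a longer chain on the amide, would compare.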